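A few compounds are considered here, and "the series" means these few. Any claim that something is new, unique, unknown or untested is made for them only; others in the source may bear on it.

Compound 3 `CC1(C)C=C(n2ccccc2=O)c2cc(C=O)ccc2O1` gives 6.14 in a functional assay (trachea) with Rattus norvegicus as the target (a lower number here means a less potent compound, a higher number a more potent compound, by a factor of ten per unit of this negative logarithm), the second highest of three numbers. Its nearest neighbour is compound 2 `Cc1ccccc1C(=O)c1ccc2c(c1)C(n1ccccc1=O)=CC(C)(C)O2`, which gives 6.25 in this assay, and the furthest is compound 1 `COc1ccc2c(c1)C(n1ccccc1=O)=CC(C)(C)O2`, which gives 5.99. Each measured step altered the group at the same aromatic carbon: a number 0.26 log units higher from compound 1 to compound 2 (within the scatter), a number 0.15 log units higher from compound 1 to compound 3 (within the scatter) and a number 0.11 log units lower from compound 2 to compound 3 (within the scatter), all within the scatter. Compound 4 `CC1(C)C=C(n2ccccc2=O)c2cc(C=C(C#N)C#N)ccc2O1` differs from compound 3 by 2,2-dicyanoethenyl in place of formyl on an aromatic carbon. Among the compounds with values here, no measured step introduces this group, but every change at that position so far has stayed within the scatter, so for compound 4 a step of about a number 0.06 log units higher from compound 3 to compound 4 (within the scatter) is expected, not beyond the scatter. Compound 4 is therefore estimated at 6.2, between 5.7 and 6.7.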

Compound 4, logarithm of the reciprocal of the active concentration, log(1/C): 6.3
Beside the measured number, compound 4's estimate is 0.10 log units below it; the range from low to high includes it.
By their numbers in this assay, from the lowest: compounds 1, 3, 2 and 4 (each within the scatter of the next, the first and the last beyond it).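

At this aromatic carbon in this assay, 2,2-dicyanoethenyl in place of formyl gives a number 0.16 log units higher from compound 3 to compound 4 (within the scatter) and in place of (2-methylphenyl)carbonyl gives a number 0.05 log units higher from compound 2 to compound 4 (within the scatter), so it cannot be told apart from either carbonyl group. Against methoxy, however, it gives a number 0.31 log units higher from compound 1 to compound 4 (beyond the scatter), the first step at this position to pass the scatter, and only modestly. No evidence is available to explain this difference.

Going by these compounds, whether an amine or a carboxylic acid at this carbon would stay in the same narrow range remains open. So does whether a longer chain ending in nitrile would match 2,2-dicyanoethenyl.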